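Enyne in place of diyne at the chain end

The source may hold more compounds than are shown below. What is called first, only, known or untested is meant among the compounds shown, and "the series" means these compounds.

Measured so far: compound 1 `O=C(O)CCCCCCCC#CC#CC#CC#C[C@@H](O)CO` gives 19.4 ug/mL in a functional assay on SW626 cells (Homo sapiens) for cytotoxicity; a lower number here means that less compound is needed, a higher number that more compound is needed for the effect; compound 2 `C[C@H](O)C#CC#CC#CC#CCCCCCCCC(=O)O` gives 4.1 ug/mL in this assay.

Going by the values given here, compound 2 holds the lowest of the two numbers in this assay, with compound 1 as its only neighbour, reached by a 4.7-fold lower number from compound 1 to compound 2 (0.68 log units; beyond the scatter). The unmeasured compound 3 `C[C@H](O)/C=C/C#CC#CC#CCCCCCCCC(=O)O` differs from compound 2 in one place: 3-hydroxybut-1-en-1-yl in place of 3-hydroxybut-1-yn-1-yl on a triple-bonded carbon. Among the compounds with values here, no measured step concerns this kind of change; the one step known, a 4.7-fold lower number from compound 1 to compound 2 (0.68 log units; beyond the scatter), removes a hydroxy group and says nothing about trading a triple bond for a double bond at the end of the conjugated chain. The shared core of compound 2 and compound 3 is otherwise the same, and the hydroxy group and the stereocentre are kept. On this basis compound 3 is expected to stay close to compound 2 in this assay, with a step of a 1.5-fold higher number from compound 2 to compound 3 (0.17 log units; within the scatter) that is estimated to be small and may fall within the scatter. Compound 3 is therefore estimated at 6 ug/mL in this assay, within a range from 2 ug/mL to 18 ug/mL.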

Compound 3, concentration for half-maximal effect: 0.36 ug/mL
Compound 3: middle estimate off by 17-fold (1.22 log units), on the high side; the measured number lies below the stated range.
By their numbers in this assay, from the lowest: compound 3; then compound 2; then compound 1.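

At this position, on a triple-bonded carbon, trading 3-hydroxybut-1-yn-1-yl for 3-hydroxybut-1-en-1-yl gives a large step in this assay, an 11-fold lower number from compound 2 to compound 3 (1.06 log units; beyond the scatter), whereas the earlier change, the loss of a hydroxy group at the chain end, gave a modest one, a 4.7-fold lower number from compound 1 to compound 2 (0.68 log units; beyond the scatter). The entering and leaving groups match in their counts of heavy atoms, hydrogen-bond donors and acceptors and defined stereocentres, so this end of the chain responds strongly to a double bond standing in place of a triple bond, and the replacement of 3,4-dihydroxybut-1-yn-1-yl by the same group gives a 54-fold lower number from compound 1 to compound 3 (1.73 log units; beyond the scatter). No measurement at hand accounts for the size of this step.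

The compounds shown leave open whether a 3,4-dihydroxybut-1-en-1-yl group would pay the same price for its extra hydroxy group as the triple-bonded pair did, and whether an amine in place of the hydroxy group of 3-hydroxybut-1-en-1-yl would keep the number in this assay. They also leave open how a methyl ester in place of the carboxylic acid would fare alongside this double bond.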